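From compound 1 to compound 3 in gastric cell inhibition

The source may hold more compounds than are shown below. What is called first, only, known or untested is meant among the compounds shown, and "the series" means these compounds.

Measured so far:
compound 1, `Cc1cc(Nc2cc(-c3ccccc3)[nH]n2)n2nc(SCc3ccc([N+](=O)[O-])cc3)nc2n1`: 43600 nM
compound 2, `Cc1cc(Nc2ccn(Cc3nc(C)c4ccccc4n3)n2)n2nc(SCc3ccc(Br)cc3)nc2n1`: 36800 nM

In an ADME assay on GES1 cells (Homo sapiens) for inhibition, read by MTT assay, with a stated time of 72 h (on this read-out lower numbers stand for stronger inhibition and higher numbers for weaker inhibition), compound 1 gives 43600 nM, the higher of the two numbers recorded. Compound 2 gives 36800 nM, and the gap between the two lies within the scatter, so neither can be ranked against the other. Compound 3, `Cc1cc(Nc2cc(-c3ccccc3)[nH]n2)n2ncnc2n1`, has not yet been measured in this assay. It differs from compound 1 in one place: hydrogen in place of (4-nitrobenzyl)sulfanyl on an aromatic carbon. Going by the values given here, no step between two measured compounds that differ in a single place is available, so the expectation rests on compound 1 alone. Because compound 1 gives 43600 nM, already at the weak end, removal of the (4-nitrobenzyl)sulfanyl group is expected to leave inhibition weak or weaken it further, a step of a 1.5-fold higher number from compound 1 to compound 3 (0.17 log units; within the scatter) toward a higher number, possibly beyond the scatter. Compound 3 is therefore estimated at 65000 nM, within a range of 25000 nM to 170000 nM.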

Compound 3, half-maximal inhibitory concentration: > 50000 nM
Compound 3: no number, only a limit; the forecaster's own chance of this, stated with the estimate: 30%; the middle value is on the limit's open side.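

In this assay compound 3 gives > 50000 nM, which is a limit of the assay and not a number. On the aromatic carbon between two ring nitrogen atoms, hydrogen in place of (4-nitrobenzyl)sulfanyl brings no sign of stronger inhibition, and the record reads an at least 1.1-fold higher number from compound 1 to compound 3 (0.05 log units; that floor lies within the scatter). The true size of this step cannot be read, so the (4-nitrobenzyl)sulfanyl group may matter little or much here: the limit of > 50000 nM in this assay, at which 1 of the 3 values shown sits.

The compounds shown leave open how a small group such as methylsulfanyl, or an amine, on this same carbon would read in this assay. They also leave open whether the nitro group or the benzyl part of the lost group counts for more, as a plain benzylsulfanyl group does not stand among them.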